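The compounds below may be only part of what the source reports. "The series", "measured", "known", "first", "only" and "open" are said of these compounds alone.

In a functional assay on SH-SY5Y cells (Homo sapiens) for antagonist activity, read by cAMP accumulation (on this read-out higher numbers stand for higher potency (the scale is a negative logarithm) and lower numbers for lower potency), two compounds sharing one core have been measured so far. Within the data shown here, compound 1 `CC(C)Oc1ccc(Cc2ccc(NC3=NCCN3)cc2)cc1` gives 8.8, and compound 2 `CC(C)COc1ccc(Cc2ccc(NC3=NCCN3)cc2)cc1` gives 8.8, which places compound 2 level with compound 1, its only measured neighbour. Still unmeasured is compound 3 `CCCCCCOc1ccc(Cc2ccc(NC3=NCCN3)cc2)cc1`, which differs from compound 2 only on the oxygen on the aromatic ring, where isobutoxy gives way to hexyloxy: pentyl in place of isopropyl on a saturated chain carbon bound to an oxygen on an aromatic ring. Cut one bond further out, the same difference reads isobutyl to hexyl. Among the measured compounds shown here, only one measured step bears on this change, the swap of isopropyl for isobutyl on that same oxygen. That swap is a modest one, and no chain as large as hexyl has yet been measured, so the guide is thin and a drop cannot be ruled out. Since the swap gave no change at the digits printed from compound 1 to compound 2 (within the scatter), the expected result is a number 0.20 log units lower from compound 2 to compound 3 (within the scatter), which means no step beyond the scatter, with a slight lean towards lower potency. Compound 3 is estimated at 8.6, with an expected range from 8 to 9.1.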

Compound 3, negative logarithm of the antagonist equilibrium constant: 8.2
Compound 3: the middle estimate sits 0.40 log units above what was measured; the range from low to high includes it.
By their numbers in this assay, from the lowest: compound 3; then compounds 1 and 2 (each within the scatter of the next).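

Among these compounds, on an oxygen on an aromatic ring, the chain is not freely interchangeable: in this assay hexyl in place of isobutyl gives a number 0.60 log units lower from compound 2 to compound 3 (beyond the scatter) and is the first change here to go beyond the scatter. Hexyl in place of isopropyl gives a number 0.60 log units lower from compound 1 to compound 3 (beyond the scatter) as well, so the hexyl compound stands apart from both compounds with shorter, branched chains, while those two remain level with each other. The position therefore tolerates the small swap from isopropyl to isobutyl but not the full change to hexyl, although the loss is modest and nothing given here explains it.

Open, going by these compounds, is where between isobutyl and hexyl the fall sets in, which a butyl or pentyl chain on this oxygen could show, and whether an octyl chain would lower the number further. Also open, on these data alone, is whether length or the absence of branching matters more, and how a chain ending in an amine or a carboxylic acid would behave at this same place.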